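A new chain on the oxygen of compound 2

The source may report more compounds than this note shows. Statements on the series, on what has been measured and on what is new or still open speak of the compounds shown alone.

Compound 1 `CC(C)(C)CCOc1cccc(O)c1C(=O)/C=C/c1ccc(C(=O)O)cc1`: 5440 nM
Compound 2 `CCCCCCOc1cccc(O)c1C(=O)/C=C/c1ccc(O)cc1`: > 30000 nM (a limit of the assay)

Both compounds were tested in a functional assay on NUGC-3 cells (Homo sapiens) for antiproliferative activity, read by sulforhodamine B assay; a lower number here means a stronger inhibitor of growth, a higher number a weaker inhibitor of growth. Compound 1 gives a measured number there, 5440 nM. Compound 2 stands at > 30000 nM in this assay, which is a limit of the assay and not a number.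

Compound 3 `CC(C)=CCOc1cccc(O)c1C(=O)/C=C/c1ccc(O)cc1` departs from compound 2 in one place: 2-methylprop-1-en-1-yl in place of pentyl on a saturated chain carbon bound to an oxygen on an aromatic ring. 2-Methylprop-1-en-1-yl stands in place of pentyl on a saturated chain carbon bound to an oxygen on an aromatic ring. Cut one bond further out, hexyloxy gives way to (3-methylbut-2-en-1-yl)oxy.

Among the compounds with values here, no measured pair isolates this change, so the expectation has little to rest on. It starts from compound 2, whose > 30000 nM is a limit. In this assay only a small step is expected, if any, towards stronger growth inhibition, leaving compound 3 a weak inhibitor. The expected step is an at least 1.2-fold lower number from compound 2 to compound 3 (0.09 log units; that floor lies within the scatter). For compound 3 the estimate is 24000 nM, within an expected range of 10000 nM to 45000 nM.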

Compound 3, concentration for 50% growth inhibition: > 30000 nM
Compound 3 was reported as a limit (the forecaster's own chance of this, stated with the estimate: 55%); middle value at least 1.2-fold (0.09 log units) from the limit.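

In this assay compound 3 gives > 30000 nM, which is a limit of the assay and not a number. No step from compound 2 to compound 3 can be read, because both compounds rest on the same limit: the limit of > 30000 nM in this assay, at which 2 of the 3 values shown sit.

The compounds shown leave open how far hexyloxy and (3-methylbut-2-en-1-yl)oxy actually differ in growth inhibition.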